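Methylamino in place of chloro on compound 1

This account rests on a few compounds, and the source may have more. Where it says the series, first, only, none or still open, it means among the compounds named here.

In a functional assay on MCF7 cells (Homo sapiens), read by colorimetric assay, with a stated time of 96 h (a higher number here means a weaker inhibitor, a lower number a stronger inhibitor), compound 1 `OC[C@@H](O)[C@H]1O[C@@H](n2cnc3c(Cl)ncnc32)[C@H](O)[C@@H]1O` gives > 100000 nM as its reading, which is a limit of the assay and not a number. Compound 3 `Nc1nc(Cl)nc2c1ncn2[C@@H]1O[C@H]([C@H](O)CO)[C@@H](O)[C@H]1O` gives > 100000 nM as its reading, which is also a limit. Compound 1 therefore stands at the limit of > 100000 nM in this assay, at which 2 of the 3 values shown sit, and has no measured number of its own. Compound 2 `OC[C@@H](O)[C@H]1O[C@@H](n2cnc3c(Cl)nc(Cl)nc32)[C@H](O)[C@@H]1O` gives 54200 nM as a true number. Chloro in place of hydrogen gave an at least 1.8-fold lower number from compound 1 to compound 2 (0.26 log units; that floor lies within the scatter) and amino in place of chloro gave an at least 1.8-fold higher number from compound 2 to compound 3 (0.26 log units; that floor lies within the scatter) in turn, and the second of these is the nearer precedent.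

Compound 4 `CNc1ncnc2c1ncn2[C@@H]1O[C@H]([C@H](O)CO)[C@@H](O)[C@H]1O` differs from compound 1 by methylamino in place of chloro on an aromatic carbon with methylamino in place of chloro on an aromatic carbon. Because an at least 1.8-fold higher number from compound 2 to compound 3 (0.26 log units; that floor lies within the scatter) is the nearest measured change, the expected step of a number no higher from compound 1 to compound 4 (the limit leaves the size open) in this assay stays within the scatter, in neither direction. A reading given only as a limit is the likeliest outcome. For compound 4 the estimated value is 100000 nM with an expected range of 45000 nM to 220000 nM in all.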

Compound 4, half-maximal inhibitory concentration: > 100000 nM
Compound 4: no number, only a limit; the forecaster's own chance of this, stated with the estimate: 75%; the middle value sits exactly at the limit.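

The step from compound 1 to compound 4 cannot be read, since both readings are limits of the assay and neither is a number: the limit of > 100000 nM in this assay, at which 3 of the 4 values shown sit.

The compounds shown leave open where compound 1 and compound 4 truly lie in this assay, and so what methylamino in place of chloro does there.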